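Chloro to Methoxy on Two Related Cores

The source may hold more compounds than are shown below. What is called first, only, known or untested is meant among the compounds shown, and "the series" means these compounds.

Measured compounds:
Compound 1 `COc1cc2c(/C=C3/C(=O)Nc4ccc(Cl)cc43)c(Cl)n(Cc3cc(OC)c(OC)c(OC)c3)c2cc1C` gives 5620 nM in a functional assay on cells (Cancer cell lines, Homo sapiens) for cytotoxicity, with a stated time of 48 h; on this read-out higher numbers stand for weaker inhibition of growth and lower numbers for stronger inhibition of growth.
Compound 2 `COc1ccc2c(c1)/C(=C\c1c(Cl)n(Cc3cc(OC)c(OC)c(OC)c3)c3cc(C)c(OC)cc13)C(=O)N2` gives 85100 nM in this assay.
Compound 3 `COc1c(/C=C2/C(=O)Nc3ccc(Cl)cc32)c2ccccc2n1-c1ccccc1` gives 25700 nM in this assay.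

Compound 4 `COc1ccc2c(c1)/C(=C\c1c(OC)n(-c3ccccc3)c3ccccc13)C(=O)N2` has not yet been measured. It differs from compound 3 by methoxy in place of chloro on an aromatic carbon. The same change was already made once: compound 2 differs from compound 1 by methoxy in place of chloro on an aromatic carbon, and that step gave a 15-fold higher number from compound 1 to compound 2 (1.18 log units; beyond the scatter). The place of the change is the same in both pairs; how the core of compound 3 differs from the core of compound 1 is not broken down here.

Because the earlier step was a 15-fold higher number from compound 1 to compound 2 (1.18 log units; beyond the scatter), a step of similar direction is expected here, as a 7.8-fold higher number from compound 3 to compound 4 (0.89 log units; beyond the scatter). On that basis compound 4 is estimated at 200000 nM, within 50000 nM to 800000 nM.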

Compound 4, concentration for total growth inhibition: 11000 nM
For compound 4 the middle estimate is 18-fold (1.26 log units) above the measured one, outside the stated range (below it).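

In this assay, putting methoxy in place of chloro gave a 2.3-fold lower number from compound 3 to compound 4 (0.37 log units; beyond the scatter), which here means somewhat stronger inhibition of growth. Among these compounds, the same change therefore did not carry over from one core to the other, not even in direction: the same change on two cores in this assay, a 15-fold higher number (1.18 log units; beyond the scatter) from compound 1 to compound 2 and a 2.3-fold lower number (0.37 log units; beyond the scatter) from compound 3 to compound 4, 35-fold (1.55 log units) apart, beyond the scatter of two such steps This shows that, in these two pairs, the outcome of the change depends on the core, but with only two pairs it does not show which of the differences between the cores matters, or what the change would do on a third core.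

The compounds shown leave open how an amine or a carboxylic acid in the same place would behave on either core.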